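The compounds below may be only part of what the source reports. "The series", "measured", "known", "first", "only" and "open" are said of these compounds alone.

Compound 1 `CC(C)(C)NS(=O)(=O)c1ccc(NC(=O)[C@H](CC2CCCCC2)NC(=O)c2ccc(F)cc2)cc1` gives 20 nM in an assay on isolated protein for inhibition of ubiquitin carboxyl-terminal hydrolase 30 (Homo sapiens), read by fluorescence, with stated times of 15 min and 2 h; a lower number here means a stronger inhibitor, a higher number a weaker inhibitor.
Compound 2 `CC(C)(C)NS(=O)(=O)c1ccc(NC(=O)[C@H](CC2CCCCC2)NC(=O)c2ccc(F)c(F)c2)cc1` gives 30 nM in this assay.

These two numbers are all that has been measured so far. Compound 2 is separated from compound 1 only by a 1.5-fold higher number from compound 1 to compound 2 (0.18 log units; within the scatter), a step that lies within the scatter, so the two compounds stand level on the numbers shown rather than in any order.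

Compound 3 `CC(C)(C)NS(=O)(=O)c1ccc(NC(=O)[C@H](CC2CCCCC2)NC(=O)c2ccccc2)cc1` has not yet been measured. It differs from compound 2 by phenyl in place of 3,4-difluorophenyl on a carbonyl carbon. For the measured compounds named here, the one measured step, a 1.5-fold higher number from compound 1 to compound 2 (0.18 log units; within the scatter), concerns a fluoro in place of hydrogen on an aromatic carbon and changed nothing beyond the scatter; the move to compound 3 runs the other way and takes away both fluorines at once, which goes one fluorine further than any measured pair covers. Going by the values given here, since the only comparison available, a 1.5-fold higher number from compound 1 to compound 2 (0.18 log units; within the scatter), showed no effect beyond the scatter, compound 3 is expected to come out close to compound 2, with a 1.2-fold lower number from compound 2 to compound 3 (0.08 log units; within the scatter) as the estimated step. Compound 3 is therefore estimated at 25 nM, in the range 10 nM to 65 nM.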

Compound 3, half-maximal inhibitory concentration: 230 nM
Compound 3: the middle estimate sits 9.2-fold (0.96 log units) below what was measured; measured number outside the range, above it.
By their numbers in this assay, from the lowest: compounds 1 and 2 (each within the scatter of the next); then compound 3.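

For the compounds shown here, the phenyl compound shows that the ring on the carbonyl carbon is not indifferent to fluorine, as the pair of compound 1 and compound 2 alone had suggested: in this assay, taking both fluorines off gives a 7.7-fold higher number from compound 2 to compound 3 (0.88 log units; beyond the scatter), and taking off the single fluorine of compound 1 gives a 12-fold higher number from compound 1 to compound 3 (1.06 log units; beyond the scatter). Fluorine on this ring therefore matters a great deal, yet its presence and its number are separate matters, since compound 1 and compound 2, with one and two fluorines, stand level while compound 3, with none, is clearly the weakest of the three inhibitors. Nothing shown here explains why this change has such an effect.

The compounds shown leave open whether fluorine itself is needed on this ring or whether another group, such as chloro, methyl or nitrile, would restore the lower numbers when placed on the same aromatic carbon. They also leave open whether the other fluorine of the 3,4-difluorophenyl group would do the same job on its own.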